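Lengthening the amine substituent from compound 3 to compound 4

The source may report more compounds than this note shows. Statements on the series, on what has been measured and on what is new or still open speak of the compounds shown alone.

Of the compounds shown here, three have been measured in an assay on CHO cells for displacement of a labelled ligand from C-X-C chemokine receptor type 3 (Homo sapiens), with a stated time of 60 min; on this read-out higher numbers stand for weaker inhibition and lower numbers for stronger inhibition. Compound 1 `CCN(Cc1ccc(OCCN2C(=O)CCC2=O)c(C)c1)C(CC(=O)O)c1ccc(Cl)cc1` gives 424 nM. Compound 2 `Cc1cc(CN(CC2CCCCC2)C(CC(=O)O)c2ccc(Cl)cc2)ccc1OCCN1C(=O)CCC1=O` gives 81 nM, and the step from compound 1 to compound 2 is a 5.2-fold lower number from compound 1 to compound 2 (0.72 log units; beyond the scatter), that is, cyclohexyl in place of methyl on a saturated chain carbon bound to an amine nitrogen. Compound 3 `Cc1cc(CN(C)C(CC(=O)O)c2ccc(Cl)cc2)ccc1OCCn1c(=O)ccn(C)c1=O` gives 1300 nM, the highest of the three numbers; compound 1 is nearest to it, compound 2 furthest. Compound 1 differs from compound 3 in two places, so its value alone cannot be tied to either change.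

Compound 4 `CCN(Cc1ccc(OCCn2c(=O)ccn(C)c2=O)c(C)c1)C(CC(=O)O)c1ccc(Cl)cc1` carries the change methyl in place of hydrogen on a saturated chain carbon bound to an amine nitrogen relative to compound 3. For the measured compounds named here, no measured pair shows exactly this change. The nearest guide is the step from compound 1 to compound 2, where a larger group on the same kind of carbon gave a clearly lower number. A smaller growth here is therefore expected to give a smaller gain. For compound 4 the expected step is a 2.4-fold lower number from compound 3 to compound 4 (0.37 log units; beyond the scatter), and the estimated value is 550 nM, with a range from 200 nM to 1400 nM.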

Compound 4, half-maximal inhibitory concentration: 428 nM
Compound 4: middle estimate off by 1.3-fold (0.11 log units), on the high side; the measured number falls inside the stated range.
By their numbers in this assay, from the lowest: compound 2; then compounds 1 and 4 (each within the scatter of the next); then compound 3.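

In this assay, methyl in place of hydrogen on a saturated chain carbon bound to an amine nitrogen gives a step beyond the scatter (a 3.0-fold lower number from compound 3 to compound 4 (0.48 log units; beyond the scatter)), so even this small growth counts at this place. Together with the cyclohexyl step (a 5.2-fold lower number from compound 1 to compound 2 (0.72 log units; beyond the scatter)), it gives a lower number for a larger group in both measured pairs, even though the two pairs carry different ring groups at the far end of the molecule. That far-end swap itself does not separate the compounds (a 1.0-fold higher number from compound 1 to compound 4 (0.00 log units; within the scatter)), so the six-membered aromatic ring group and the five-membered non-aromatic ring group cannot be told apart here.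

Still open, going by these compounds, is whether a propyl chain or a cyclopropyl group at this place would fit the same trend. Nothing available explains why the number responds to growth here.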